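The source may report more compounds than this note shows. Statements on the series, on what has been measured and on what is new or still open speak of the compounds shown alone.

In a functional assay on ileum (Cavia porcellus) for antagonist activity (a lower number here means a stronger inhibitor, a higher number a weaker inhibitor), compound 1 `O=C(O)c1ccc(OCCCOc2ccc3c(O)c([N+](=O)[O-])c(=O)oc3c2)cc1` reports only a limit, > 20000 nM. Going by the values given here, compound 2 `Cc1ccc(OCCCOc2ccc3c(O)c([N+](=O)[O-])c(=O)oc3c2)cc1` gives 4500 nM, the only exact number so far. Compound 3 `Cc1cccc(OCCCOc2ccc3c(O)c([N+](=O)[O-])c(=O)oc3c2)c1` differs from it by 3-methylphenyl in place of 4-methylphenyl on an oxygen on a saturated carbon. Among the compounds with values here, the one measured step, an at least 4.4-fold lower number from compound 1 to compound 2 (0.64 log units; beyond the scatter), exchanged carboxy for methyl, so it bears only indirectly on this change of methyl position, and no measured step shows that change directly. The expected step, a 1.1-fold lower number from compound 2 to compound 3 (0.05 log units; within the scatter), is estimated to stay within the scatter. The expected value for compound 3 is 4000 nM, within a range of 1500 nM to 12000 nM.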

Compound 3, half-maximal inhibitory concentration: 4400 nM
Compound 3: middle estimate off by 1.1-fold (0.04 log units), on the low side; the range from low to high includes it.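

In this assay, the shift of the methyl gives a 1.0-fold lower number from compound 2 to compound 3 (0.01 log units; within the scatter), so 3-methylphenyl and 4-methylphenyl on this oxygen cannot be told apart in this read-out. The gain over carboxy also holds with the methyl in its new place, at an at least 4.5-fold lower number from compound 1 to compound 3 (0.65 log units; beyond the scatter). Compound 1 reports only a limit, so the full size of that step cannot be read: the limit of > 20000 nM in this assay, at which 1 of the 3 values shown sits.

The compounds shown leave open how 2-methylphenyl or unsubstituted phenyl would compare on this oxygen. They also leave open whether a methoxy group or an amine on this ring could match methyl.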